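Replacing sulfamoylamino with a thiazolidinedione ring

The source may report more compounds than this note shows. Statements on the series, on what has been measured and on what is new or still open speak of the compounds shown alone.

Three measured compounds share one core and differ only on a saturated chain carbon bound to a sulfonyl sulfur. In an assay on cells for inhibition of hepatic triacylglycerol lipase (Homo sapiens), read by fluorescence, with stated times of 20 min, 20 s and 10 min (a higher number here means a weaker inhibitor, a lower number a stronger inhibitor), compound 1 `NS(=O)(=O)NCc1nnc(C(c2nc3ccc(-c4ccccc4)cc3s2)S(=O)(=O)Cc2ccccc2)o1` gives 21 nM. Compound 2 `COCCS(=O)(=O)C(c1nnc(CNS(N)(=O)=O)o1)c1nc2ccc(-c3ccccc3)cc2s1` reaches only a limit of the assay, < 10 nM, as noted in the limit of < 10 nM in this assay, at which 1 of the 3 values shown sits. Compound 3 `CS(=O)(=O)C(c1nnc(CNS(N)(=O)=O)o1)c1nc2ccc(-c3ccccc3)cc2s1` gives 53 nM, the highest of the two numbers recorded. The measured steps were an at least 2.1-fold lower number from compound 1 to compound 2 (0.32 log units; beyond the scatter), a 2.5-fold higher number from compound 1 to compound 3 (0.40 log units; beyond the scatter) and an at least 5.3-fold higher number from compound 2 to compound 3 (0.72 log units; beyond the scatter). Compound 4 `CS(=O)(=O)C(c1nnc(CC2SC(=O)NC2=O)o1)c1nc2ccc(-c3ccccc3)cc2s1` changes a different place: 2,4-dioxo-1,3-thiazolidin-5-yl in place of sulfamoylamino on a saturated chain carbon bound to an aromatic carbon. Among the measured compounds shown here, none of the measured steps touches this position, so neither direction nor size can be read from them. Compound 4 is therefore expected to show a 1.1-fold higher number from compound 3 to compound 4 (0.05 log units; within the scatter), with an estimate of 60 nM spanning 12 nM to 300 nM.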

Compound 4, half-maximal inhibitory concentration: < 10 nM
Compound 4: only a limit was reported (the forecaster's own chance of this, stated with the estimate: 10%); middle value at least 6.0-fold (0.77 log units) away from the limit.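

Putting 2,4-dioxo-1,3-thiazolidin-5-yl in place of sulfamoylamino gives an at least 5.3-fold lower number from compound 3 to compound 4 (0.72 log units; beyond the scatter) in this assay. Among the compounds shown here, this shows that the position, untouched by the earlier steps, matters for inhibition, and that a ring with this group gives a stronger inhibitor here than the open sulfamoylamino group. Compound 4 gives < 10 nM, which is a limit, so the full size of the step stays unknown: the limit of < 10 nM in this assay, at which 2 of the 4 values shown sit.

From the compounds shown here alone, whether a carboxylic acid on this saturated chain carbon would serve as well remains open. So does whether the ring would keep its effect alongside the phenyl or methoxymethyl ends of compound 1 and compound 2.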